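This account rests on a few compounds, and the source may have more. Where it says the series, first, only, none or still open, it means among the compounds named here.

Compound 1, `COc1cc(CCc2ccc(Br)cc2)cc(OC)c1O`, gives > 25000 nM in a functional assay on MDA-MB-231 cells (Homo sapiens) for antiproliferative activity, read by MTT assay, with a stated time of 72 h; a higher number here means a weaker inhibitor, a lower number a stronger inhibitor; this is a limit of the assay, not a measured number.
Compound 2, `COc1cc(CCc2cccc(F)c2)cc(OC)c1O`, gives > 25000 nM in this assay, again only a limit.
Compound 3, `COc1ccc(CCc2ccccc2Cl)cc1OC`, gives > 25000 nM in this assay, again only a limit.

Compound 1 therefore stands nowhere in particular on a scale of numbers: its result is the limit of > 25000 nM in this assay, at which 3 of the 3 values shown sit, so all three measured compounds sit at the same ceiling of this assay, and none of them is told apart from the others by the data. Going by the values given here, no step between two measured compounds can be computed from such limits.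

The new compound, compound 4, `COc1cc(CCc2ccc(Cl)cc2)cc(OC)c1O`, differs from compound 1 in one place: chloro in place of bromo on an aromatic carbon. The shared core with its two methoxy groups and the hydroxyl is kept unchanged.

Since compound 1 is known only by its limit in this assay, the step from compound 1 to compound 4 is expected to be none beyond the usual scatter, a step that the limit leaves unreadable from compound 1 to compound 4. Compound 4 is estimated to give about 40000 nM in this assay, with a plausible range from 15000 nM to 150000 nM, and it is expected that the assay most likely again reports only a limit rather than a number.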

Compound 4, half-maximal inhibitory concentration: > 25000 nM
Compound 4: only a limit was reported; the forecaster's own chance of this, stated with the estimate: 85%; the middle value is on the limit's open side.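

In this assay compound 4 gives > 25000 nM, again a limit of the assay and not a number. Going by these compounds alone, compound 1 is also known only by a limit, so no step from compound 1 to compound 4 can be read: the limit of > 25000 nM in this assay, at which 4 of the 4 values shown sit. The compounds shown leave open how they rank against one another, and whether chloro and bromo differ at all.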